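Aryl substitution on a shared core: notes on four compounds

The source may hold more compounds than are shown below. What is called first, only, known or untested is meant among the compounds shown, and "the series" means these compounds.

All numbers below come from an assay on mitochondria from L6 cells (Rattus norvegicus) for activation, with a stated time of 90 min; a lower number here means that less compound is needed, a higher number that more compound is needed for the effect.

- compound 1, `Oc1nc2nonc2nc1Nc1ccccc1F`: 12500 nM
- compound 2, `Oc1nc2nonc2nc1Nc1ccccc1`: 66700 nM
- compound 3, `CCc1ccc(Nc2nc3nonc3nc2O)cc1`: 10700 nM

Compound 2 carries an unsubstituted phenyl ring on the shared core and gives the highest of the three numbers. Two single changes on that ring have been measured. The first is fluoro in place of hydrogen on an aromatic carbon, which gave a 5.3-fold lower number from compound 2 to compound 1 (0.73 log units; beyond the scatter). The second is ethyl in place of hydrogen on an aromatic carbon, which gave a 6.2-fold lower number from compound 2 to compound 3 (0.79 log units; beyond the scatter). The values of compound 1 and compound 3 lie within the scatter of each other, so no order between them is claimed.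

Compound 4, `CCc1ccc(Nc2nc3nonc3nc2O)c(F)c1`, is not yet measured. It differs from compound 3 by fluoro in place of hydrogen on an aromatic carbon. For the measured compounds named here, this is the same kind of change as the one from compound 2 to compound 1, but the surroundings differ: in compound 4 the entering fluoro is also meta to an ethyl group, whereas in compound 1 it is only ortho to a large group. The cores of compound 2 and compound 3 differ only by the ethyl group already described.

Going by the values given here, for compound 4 the expectation is a step of a 3.6-fold lower number from compound 3 to compound 4 (0.55 log units; beyond the scatter) in this assay, somewhat smaller than the step that the same change made from compound 2 to compound 1, because the reference point of compound 3 is already 10700 nM and only one earlier example of this change exists. The estimated value for compound 4 is 3000 nM, within 1000 nM to 12000 nM.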

Compound 4, half-maximal effective concentration: 6700 nM
Beside the measured number, compound 4's estimate is 2.2-fold (0.35 log units) below it; low and high end bracket the measured number.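

In this assay, fluoro in place of hydrogen on an aromatic carbon gives a 1.6-fold lower number from compound 3 to compound 4 (0.20 log units; within the scatter), and ethyl in place of hydrogen on an aromatic carbon gives a 1.9-fold lower number from compound 1 to compound 4 (0.27 log units; within the scatter), so compound 4 is not separated from either of these two neighbours. The fluoro change does not keep its size when carried from the unsubstituted ring of compound 2 to the ethyl-bearing ring of compound 3: the same change on two cores in this assay, a 5.3-fold lower number (0.73 log units; beyond the scatter) from compound 2 to compound 1 and a 1.6-fold lower number (0.20 log units; within the scatter) from compound 3 to compound 4, 3.3-fold (0.52 log units) apart, beyond the scatter of two such steps. This shows that, on these four compounds, the two changes do not simply add up; it does not show how either change would behave on any other ring, and the ethyl comparison, drawn from the same four compounds, is no independent check: the same change on two cores in this assay, a 6.2-fold lower number (0.79 log units; beyond the scatter) from compound 2 to compound 3 and a 1.9-fold lower number (0.27 log units; within the scatter) from compound 1 to compound 4, 3.3-fold (0.52 log units) apart, beyond the scatter of two such steps.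

The compounds shown leave open whether the smaller fluoro step is tied to the ethyl group itself or would also appear with a methyl group, a longer chain or a methoxy group in its place. Also open, going by these compounds, is how an amine or a carboxylic acid on the ring would read in this assay, and whether the fluoro change would hold its size beside such groups.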